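A few compounds are considered here, and "the series" means these few. Any claim that something is new, unique, unknown or untested is made for them only; others in the source may bear on it.

Measured in a physicochemical assay for lipophilicity; a higher number here means a more lipophilic compound, a lower number a more polar compound:
- Compound 1 `C[C@H]1CC[C@@H]2[C@@H](OC(=O)[C@]23CC(c2ccc(F)cc2)N(c2ccccc2)O3)[C@]2(C)C(=O)C=C[C@@]12O`: 3.35
- Compound 2 `COc1ccc(C2C[C@@]3(ON2c2ccccc2)C(=O)O[C@@H]2[C@H]3CC[C@H](C)[C@]3(O)C=CC(=O)[C@@]23C)cc1`: 3.25
- Compound 3 `C[C@H]1CC[C@@H]2[C@@H](OC(=O)[C@]23CC(c2c(Cl)cccc2Cl)N(c2ccccc2)O3)[C@]2(C)C(=O)C=C[C@@]12O`: 4.45

Compound 3, at 4.45, stands highest of the three, and its distance to each of the others lies beyond the scatter. The remaining pair barely separates, with a number 0.10 log units lower from compound 1 to compound 2 (within the scatter).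

Compound 4 `C[C@H]1CC[C@@H]2[C@@H](OC(=O)[C@]23CC(c2ccccc2Cl)N(c2ccccc2)O3)[C@]2(C)C(=O)C=C[C@@]12O` keeps the core of compound 3 but carries 2-chlorophenyl instead of 2,6-dichlorophenyl. This is hydrogen in place of chloro on an aromatic carbon, ortho to a large group and meta to a chloro group (hydrogen in place of chloro on an aromatic carbon).

Going by the values given here, no measured step makes this exact change. The closest evidence is a number 1.10 log units higher from compound 1 to compound 3 (beyond the scatter) and a number 1.20 log units higher from compound 2 to compound 3 (beyond the scatter). Both are large, but each swaps a whole substituted phenyl group, so neither isolates a single chloro. Compound 4 keeps one of the two chloro groups of compound 3 and has none of the fluoro or methoxy groups of the other two compounds. A drop is therefore expected in this assay, probably beyond the scatter but clearly smaller than those two steps.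

The expected change is a number 0.55 log units lower from compound 3 to compound 4 (beyond the scatter). For compound 4 the estimated value is 3.9, with an expected range from 3.5 to 4.3.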

Compound 4, partition coefficient: 3.87
Compound 4: the middle estimate sits 0.03 log units above what was measured; the measured number falls inside the stated range.
By their numbers in this assay, from the lowest: compounds 2 and 1 (each within the scatter of the next); then compound 4; then compound 3.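

Going by these compounds alone, with one chloro taken off the 2,6-dichlorophenyl group and hydrogen left in its place, the number in this assay shifts by a number 0.58 log units lower from compound 3 to compound 4 (beyond the scatter), and this is the only step at this position that changes a single atom rather than a whole substituted phenyl group. The 2-chlorophenyl compound still stays clear of the other two, with a number 0.62 log units higher from compound 2 to compound 4 (beyond the scatter) and a number 0.52 log units higher from compound 1 to compound 4 (beyond the scatter), so the four compounds now fall into three separate levels, with the 4-fluorophenyl and 4-methoxyphenyl compounds together at the bottom, the single chloro in the middle and the two chloro groups at the top. Nothing measured here accounts for the size of these steps.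

The compounds shown leave open what taking off the remaining chloro would do, since an unsubstituted phenyl group is not among them, and so whether the second chloro counts for as much as the first. They also leave open how this position would respond to a group of another kind on the same ring, such as an amine or a carboxylic acid.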